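Expecting the Effect of a (4-Fluorophenyl)carbonyl Group on Compound 2

The compounds below may be only part of what the source reports. "The series", "measured", "known", "first", "only" and "open" are said of these compounds alone.

Two close relatives have so far been tested in a functional assay on MDA-MB-231 cells (Homo sapiens) for inhibition, read by sulforhodamine B assay, tested at 10 uM; on this read-out higher numbers stand for more inhibition at the one concentration tested (going by the name of the read-out) and lower numbers for less inhibition. Compound 1 `CN(C)c1ccc(C2CC(c3ccc(-n4cncn4)cc3)=NN2)cc1` gives 7%. Compound 2 `CN(C)c1ccc(C2CC(c3ccc(-n4ccnc4)cc3)=NN2)cc1` gives 7.6% in this assay. For the measured compounds named here, the single measured step, a number 0.6 percentage points higher from compound 1 to compound 2 (within the scatter), is within the scatter. Going by the values given here, compound 2 therefore holds the highest of the two numbers, yet its only neighbour, compound 1, lies within the scatter of it, so this assay does not tell the two apart.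

Compound 3 `CN(C)c1ccc(C2CC(c3ccc(-n4ccnc4)cc3)=NN2C(=O)c2ccc(F)cc2)cc1` has not been measured. It differs from compound 2 in one place: (4-fluorophenyl)carbonyl in place of hydrogen on an amine nitrogen in a ring. The new group brings one six-membered aromatic ring of carbon only and one hydrogen-bond acceptor, and it sits on an amine nitrogen in a ring of the shared core.

Among the compounds with values here, no measured step touches this position. Within the data shown here, the one step in hand concerns a different part of the molecule and stays within the scatter, so it offers no guide to the size or direction of the new change.

Compound 3 is accordingly expected to give 15% in this assay, with a wide range from -5% to 45%. The expected step of a number 7.4 percentage points higher from compound 2 to compound 3 (within the scatter) is, on this footing, estimated to have no confident direction beyond the scatter.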

Compound 3, a percentage reported as inhibition, at one concentration (the size of the read-out at that concentration, not a potency): 9.4%
Estimate against measurement, compound 3: 5.6 percentage points above; low and high end bracket the measured number.
By their numbers in this assay, from the lowest: compounds 1, 2 and 3 (each within the scatter of the next).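

In this assay, for the compounds shown here, placing (4-fluorophenyl)carbonyl instead of hydrogen on the amine nitrogen in the ring gives a number 1.8 percentage points higher from compound 2 to compound 3 (within the scatter) and is the first measured step at this position. Here, a group bringing a six-membered aromatic ring of carbon only and a hydrogen-bond acceptor does not separate compound 3 from compound 2 on this read-out, so the change at this nitrogen, like the earlier swap of triazolyl for imidazolyl, gives no difference that can be told from the scatter. No measurement at hand offers an explanation for this outcome.

As far as these compounds go, what an acetyl group, a plain benzoyl group or a longer alkyl chain on this nitrogen would give remains open, as does whether (4-fluorophenyl)carbonyl would behave in the same way on compound 1. Also open, from the compounds shown here alone, is how these compounds would compare at other concentrations, as a reading at one concentration shows the size of the effect there and not a potency.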